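Swapping an amide for a methyl ester on a potent inhibitor

A few compounds are considered here, and "the series" means these few. Any claim that something is new, unique, unknown or untested is made for them only; others in the source may bear on it.

Measured so far:
Compound 1, `NC(=O)c1cccc(-c2cnc(C(=O)CCc3ccc(-c4ccccc4)cc3)o2)n1`: 1.2 nM
Compound 2, `NC(=O)c1ccc(-c2cnc(CCCc3ccc(-c4ccccc4)cc3)o2)nc1`: 30000 nM
Compound 3, `O=C(O)c1cccc(-c2cnc(C(=O)CCc3ccc(-c4ccc(CN5CCCC5)cc4)cc3)o2)n1`: 130 nM

In an assay for inhibition of Fatty-acid amide hydrolase 1 (Rattus norvegicus) (a lower number here means a stronger inhibitor, a higher number a weaker inhibitor), compound 1 gives 1.2 nM, the lowest of the three numbers, so it is the strongest inhibitor of this group; the nearest neighbour is compound 3 with 130 nM, and compound 2 lies far off with 30000 nM, both gaps well beyond the scatter. Among the compounds with values here, compound 3 shares the ketone link of compound 1 but carries a carboxylic acid and a different tail, so no single-change step can be drawn from it. The unmeasured compound 4, `COC(=O)c1cccc(-c2cnc(C(=O)CCc3ccc(-c4ccccc4)cc3)o2)n1`, differs from compound 1 in one place only: methoxy in place of amino on a carbonyl carbon. The change is small in atom count, and the shared core and ketone link are kept. The step is expected to be a 13-fold higher number from compound 1 to compound 4 (1.10 log units; beyond the scatter), a modest loss, since compound 3 shows that a change at this carbonyl can cost potency while leaving a good inhibitor. In this assay compound 4 is expected to give 15 nM, within 3 nM to 80 nM.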

Compound 4, inhibition constant: 1.2 nM
Compound 4: the middle estimate sits 13-fold (1.10 log units) above what was measured; the measured number lies below the stated range.
By their numbers in this assay, from the lowest: compounds 1 and 4 (each within the scatter of the next); then compound 3; then compound 2.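

Within the data shown here, putting methoxy in place of amino on a carbonyl carbon gives no change at the digits printed from compound 1 to compound 4 (within the scatter) in this assay, the first single-change step at this position, as compound 3 differs from compound 1 in more than one place. At this position, then, the amino group and the one hydrogen-bond donor it carries can be exchanged for methoxy, which has no such donor, with no loss in this read-out, so that donor is not required for a number as low as that of compound 1. No measurement here accounts for why the two groups match.

The compounds shown leave open whether a carboxylic acid on this carbonyl, with the rest of compound 1 unchanged, would match as well. Also open, from the compounds shown here alone, is how a larger ethoxy group or a methylamino group would fare in the same place.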